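The source may hold more compounds than are shown below. What is called first, only, known or untested is meant among the compounds shown, and "the series" means these compounds.

Measured compounds:

compound 1, `CCN(Cc1cccs1)C(=O)COc1ccc(F)cc1`, 422 nM
compound 2, `Cc1ccc(OCC(=O)N(Cc2cccs2)CC(C)C)cc1`, 900 nM

Both compounds were tested in an assay on HEK293 cells for agonist activity at transient receptor potential cation channel subfamily M member 8 (Homo sapiens), read by fluorescence and calcium flux, with a stated time of 15 min; on this read-out lower numbers stand for an effect already at smaller amounts and higher numbers for an effect only at larger amounts of compound. Compound 1 has the lowest of the two numbers; the nearest is compound 2, whose number is higher by a gap that lies beyond the usual scatter of this measurement. Compound 3, `CCc1ccc(OCC(=O)N(CC)Cc2cccs2)cc1`, has not yet been measured. It differs from compound 1 in one place: ethyl in place of fluoro on an aromatic carbon. The fluoro sits on an aromatic carbon of a six-membered aromatic ring of carbon only, para to a large group, and the ethyl takes exactly that position. For the measured compounds named here, no pair of measured compounds shows this change alone, so the size of the step cannot be read from a measured pair. Compound 2 carries a methyl on the same ring but also a different chain on the nitrogen, so its number does not isolate the ring change. The step from compound 1 to compound 3 is therefore expected to be small, most likely within the scatter or at most a modest rise, as estimated by a 1.4-fold higher number from compound 1 to compound 3 (0.15 log units; within the scatter). For compound 3 the expected value is 600 nM, with a likely range from 250 nM to 1500 nM.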

Compound 3, half-maximal effective concentration: 67 nM
Beside the measured number, compound 3's estimate is 9.0-fold (0.95 log units) above it, and the stated range ends above it.
By their numbers in this assay, from the lowest: compound 3; then compound 1; then compound 2.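

In this assay, ethyl in place of fluoro on an aromatic carbon, para to a large group, gives a 6.3-fold lower number from compound 1 to compound 3 (0.80 log units; beyond the scatter), so what sits at this position clearly matters for the number in this assay. The earlier compounds shown here could not show this: compound 2 carries a methyl on the same ring but also a different chain on the nitrogen, and only the new pair isolates the ring change. The compounds shown offer no measurement that would explain the step, so it stands as an observation without a known cause.

For the compounds shown here, with only one pair speaking for this position, it remains open whether a longer chain such as propyl or butyl would bring the number down further, and whether an amine or a carboxylic acid in the same place would raise it or lower it. On these data alone, it also remains open whether ethyl in place of fluoro would give a step of similar size with the different chain on the nitrogen that compound 2 carries.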